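Swapping a Furan for a Cyanophenyl on the Core

The source may report more compounds than this note shows. Statements on the series, on what has been measured and on what is new or still open speak of the compounds shown alone.

Compound 1 `Cc1ccc(-c2nc(N)c3cc(-c4ccccc4)sc3n2)o1` and compound 2 `Cc1ccc(-c2nc(N)c3cc(Cc4ccccc4F)sc3n2)o1` share a core that carries an amino group and a pendant aromatic group. In a functional assay on CHO-K1 cells for antagonist activity at adenosine receptor A1 (Homo sapiens), read by a beta-galactosidase reporter and cAMP accumulation, with stated times of 15 min and 6 h (a higher number here means a weaker inhibitor, a lower number a stronger inhibitor), compound 1 gives 520 nM. For compound 2 the result is only a limit of the assay, < 16 nM, and not a number. Among the compounds with values here, the single measured step, an at least 32-fold lower number from compound 1 to compound 2 (1.51 log units; beyond the scatter), carries the reading down to that limit (the limit of < 16 nM in this assay, at which 1 of the 2 values shown sits). Compound 3 `N#Cc1cccc(-c2nc(N)c3cc(Cc4ccccc4F)sc3n2)c1` differs from compound 2 at a different place: 3-cyanophenyl in place of 5-methylfuran-2-yl on an aromatic carbon. Within the data shown here, no measured step touches this part of the molecule, so the one measured change offers no direct guide to the size or direction of the new step. Compound 3 is nonetheless expected to remain a strong inhibitor, with a step of an at least 1.2-fold higher number from compound 2 to compound 3 (0.09 log units; that floor lies within the scatter) expected. The estimate for compound 3 in this assay is 20 nM, expected to lie between 5 nM and 80 nM.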

Compound 3, inhibition constant: < 16 nM
Compound 3: only a limit was reported; the forecaster's own chance of this, stated with the estimate: 40%; middle value at least 1.2-fold (0.09 log units) from the limit.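

Within the data shown here, compound 2 and compound 3 both stop at a limit rather than a number in this assay, so no step between them can be read: the limit of < 16 nM in this assay, at which 2 of the 3 values shown sit. From the compounds shown here alone, whether 3-cyanophenyl or 5-methylfuran-2-yl gives the stronger inhibitor stays open, as does the true strength of either compound.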